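The compounds below may be only part of what the source reports. "The series", "measured", "known", "first", "only" and "open" are said of these compounds alone.

Measured compounds:
compound 1 `CC(C)C(c1nnc[nH]1)c1ccc(-c2ccc3cccc(F)c3c2)[nH]c1=O` with 12 nM
compound 2 `CC(C)NC(=O)CC(c1ccc(-c2ccc3cccc(F)c3c2)[nH]c1=O)C(C)C` with 5.8 nM

These two compounds share a core and differ only in the group attached to a saturated chain carbon bound to an aromatic carbon and a saturated chain carbon. In an assay on CHO cells for displacement of a labelled ligand from prostaglandin E2 receptor EP3 subtype (Homo sapiens), read by radioligand binding (on this read-out higher numbers stand for weaker inhibition and lower numbers for stronger inhibition), compound 1 gives 12 nM and compound 2 gives 5.8 nM. Among the compounds with values here, on these numbers compound 2 stands lowest of the two, the only step being a 2.1-fold lower number from compound 1 to compound 2 (0.32 log units; beyond the scatter), a modest change that nonetheless lies beyond the scatter.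

Compound 3 `CC(C)C(/C=C1\CCNC1=O)c1ccc(-c2ccc3cccc(F)c3c2)[nH]c1=O` has not been measured. It differs from compound 2 by a group of 7 heavy atoms (5 carbon, 1 nitrogen, 1 oxygen; one five-membered non-aromatic ring with 1 hetero atom) in place of a group of 7 heavy atoms (5 carbon, 1 nitrogen, 1 oxygen; no ring), on a saturated chain carbon bound to an aromatic carbon and a saturated chain carbon. Within the data shown here, the one measured step that touches this same place is a 2.1-fold lower number from compound 1 to compound 2 (0.32 log units; beyond the scatter); it shows that swapping groups here moved the number only modestly. The group entering compound 3 keeps the same count of heavy atoms, of hydrogen-bond donors and of hydrogen-bond acceptors as the group it replaces, so no strong reason for a large move in this assay is seen, and a step within the scatter, a 1.4-fold higher number from compound 2 to compound 3 (0.14 log units; within the scatter), is expected. Compound 3 is estimated at 8 nM in this assay, in a range from 2.5 nM to 25 nM.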

Compound 3, inhibition constant in the prostaglandin E2 receptor EP3 subtype assay: 2.2 nM
Compound 3: the middle estimate sits 3.6-fold (0.56 log units) above what was measured; measured number below the stated range.
By their numbers in the prostaglandin E2 receptor EP3 subtype assay, from the lowest: compound 3; then compound 2; then compound 1.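

In the prostaglandin E2 receptor EP3 subtype assay swapping (isopropylcarbamoyl)methyl for the group with a five-membered non-aromatic ring gives (a 2.6-fold lower number from compound 2 to compound 3 (0.42 log units; beyond the scatter)), so at this saturated chain carbon two groups with the same heavy-atom, donor and acceptor counts can still be told apart, and those counts alone do not settle the number. The same ring-bearing group set against 4H-1,2,4-triazol-3-yl gives a larger step (a 5.5-fold lower number from compound 1 to compound 3 (0.74 log units; beyond the scatter)), so of the three groups shown here it gives the lowest number, with its steps to the other two beyond the scatter. In a physicochemical assay for solubility, in phosphate buffer, measured as kinetic solubility (on this read-out lower numbers stand for lower solubility and higher numbers for higher solubility), compound 2 gives 18000 nM and compound 3 gives 20700 nM and the same swap reads (a 1.2-fold higher number from compound 2 to compound 3 (0.06 log units; within the scatter)), so compound 2 and compound 3 cannot be told apart on that read-out.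

No measured information at hand explains why the ring-bearing group gives the lowest number. Still open, from the compounds shown here alone, is whether the ring or the extra double bond outside aromatic rings accounts for the step, and how an amine or a carboxylic acid on this saturated chain carbon would read.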